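Bromo substitution on a pair measured only at the limit

A few compounds are considered here, and "the series" means these few. Any claim that something is new, unique, unknown or untested is made for them only; others in the source may bear on it.

Compound 1, `Cc1ccc(S(=O)(=O)n2cc(-c3cc(C(F)(F)F)ccn3)c3ccccc32)cc1`, is the reference point of the series. In a functional assay on P388 cells (Mus musculus) for cytotoxicity (a higher number here means a weaker inhibitor, a lower number a stronger inhibitor), compound 1 gives > 100000 nM, which is a limit of the assay and not a number. Compound 2, `Cc1ccc(S(=O)(=O)n2cc(-c3cc(C(F)(F)F)cc(-c4cn(S(=O)(=O)c5ccc(C)cc5)c5ccccc45)n3)c3ccccc32)cc1`, is a larger relative bearing two of the same units. In this assay compound 2 gives > 100000 nM, again a limit of the assay rather than a measured number. Among the measured compounds shown here, no step between measured compounds can be computed, since both values sit at the limit of > 100000 nM in this assay, at which 2 of the 2 values shown sit. Compound 1 thus stands at the limit, with no number that would set it apart from compound 2.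

Compound 3, `Cc1ccc(S(=O)(=O)n2cc(-c3cc(C(F)(F)F)ccn3)c3cc(Br)ccc32)cc1`, is the unmeasured analogue. It differs from compound 1 by bromo in place of hydrogen on an aromatic carbon. With both measured values resting at the limit, no direction for the change is supported, and the step from compound 1 to compound 3 is expected to be none beyond the scatter, a number no higher from compound 1 to compound 3 (the limit leaves the size open). Compound 3 is expected in this assay at 100000 nM, within a range from 20000 nM to 300000 nM, and most likely to be reported again only as a limit.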

Compound 3, half-maximal inhibitory concentration: > 100000 nM
Compound 3: only a limit was reported; the forecaster's own chance of this, stated with the estimate: 80%; the middle value lies on the limit itself.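

In this assay compound 3 gives > 100000 nM, a limit of the assay and not a number. Among the compounds shown here, no step from compound 1 to compound 3 can be read, and the effect of bromo in place of hydrogen stays without a size: the limit of > 100000 nM in this assay, at which 3 of the 3 values shown sit. The compounds shown leave open whether any member of this series has a measurable value in this assay.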